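Growing the alkyl group on the sulfonyl aryl ring

The compounds below may be only part of what the source reports. "The series", "measured", "known", "first", "only" and "open" are said of these compounds alone.

Compound 3 `CC1CCN(C2CCN(S(=O)(=O)c3ccc(C(C)C)cc3)CC2)CC1` carries an isopropyl group and in a functional assay on DLD-1 cells (Homo sapiens) for antiproliferative activity, read by CellTiter-Glo, with a stated time of 72 h (a lower number here means a stronger inhibitor, a higher number a weaker inhibitor), compound 3 gives 685 nM. Among the numbers shown it stands highest: compound 1 `CC1CCN(C2CCN(S(=O)(=O)c3ccc(-c4ccc(Cl)cc4)cc3)CC2)CC1`, bearing a 4-chlorophenyl group in the same place, gives 105 nM. Compound 2 `CCc1ccc(S(=O)(=O)N2CCC(N3CCC(C)CC3)CC2)cc1`, with an ethyl group, reports a limit in this assay, > 5000 nM. Compound 4 `CC1CCN(C2CCN(S(=O)(=O)c3ccc(C(C)(C)C)cc3)CC2)CC1` differs from compound 3 by methyl in place of hydrogen on a saturated chain carbon bound to an aromatic carbon and two saturated chain carbons. The measured steps that bear on it are an at least 7.2-fold lower number from compound 2 to compound 3 (0.86 log units; beyond the scatter) and a 6.5-fold higher number from compound 1 to compound 3 (0.81 log units; beyond the scatter); the first shows that adding a carbon at this place lowered the number. Compound 4 is therefore expected to give a small step, a 1.5-fold lower number from compound 3 to compound 4 (0.18 log units; within the scatter), close to the scatter. Compound 4 is estimated at 450 nM, with a range from 150 nM to 1400 nM.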

Compound 4, half-maximal inhibitory concentration: > 5000 nM
Compound 4 ended at the assay's limit (the forecaster's own chance of this, stated with the estimate: 5%); middle value at least 11-fold (1.04 log units) away from the limit.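

The change from isopropyl to tert-butyl brought an at least 7.2-fold higher number from compound 3 to compound 4 (0.86 log units; beyond the scatter) in this assay, so adding carbon at this place does not keep lowering the number, and among the alkyl groups shown only isopropyl gives a value inside the assay's range. Set against 4-chlorophenyl, tert-butyl gives an at least 47-fold higher number from compound 1 to compound 4 (1.67 log units; beyond the scatter). The step between compound 2 and compound 4 cannot be read, because both rest on the same limit: the limit of > 5000 nM in this assay, at which 2 of the 4 values shown sit.

As far as these compounds go, whether a cyclopropyl ring or a methoxy group at this place would give a number inside that range remains open.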